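This account rests on a few compounds, and the source may have more. Where it says the series, first, only, none or still open, it means among the compounds named here.

The measured compounds and their values in a functional assay on the whole organism (stomach) with Rattus norvegicus as the target; on this read-out lower numbers stand for an effect already at smaller amounts and higher numbers for an effect only at larger amounts of compound:

compound 1, `N=C(S)CCCn1nc(-c2ccccc2)ccc1=O`: 31.9 mg/kg
compound 2, `Cc1ccc(=O)n(CCCCCC(=N)S)n1`: > 100 mg/kg
compound 3, `Cc1ccc(=O)n(CCCCC(=N)S)n1`: > 100 mg/kg

Compound 1 is the only one of the three that gives a number in this assay, 31.9 mg/kg. Compound 2 gives > 100 mg/kg in this assay, which is a limit of the assay and not a number. Compound 3 likewise gives > 100 mg/kg in this assay, again a limit of the assay and not a number. Among the compounds with values here, compound 3 therefore sits at the limit of > 100 mg/kg in this assay, at which 2 of the 3 values shown sit, and the only step that touches it, a step that the two limits leave unreadable from compound 2 to compound 3, cannot be sized.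

Compound 4, `Cc1ccc(=O)n(CCCC(=N)S)n1`, differs from compound 3 by a group of 3 heavy atoms (1 carbon, 1 nitrogen, 1 sulfur; no ring) in place of a group of 4 heavy atoms (2 carbon, 1 nitrogen, 1 sulfur; no ring), on a saturated chain carbon, three bonds along the chain from an aromatic nitrogen. Within the data shown here, the one measured step of the same kind, a step that the two limits leave unreadable from compound 2 to compound 3, gives no readable size, so no direction can be drawn from it. Compound 4 is expected to stay near the limit, with a number no higher from compound 3 to compound 4 (the limit leaves the size open) as the estimated step; compound 4 is estimated at 100 mg/kg, ranging from 30 mg/kg to 300 mg/kg.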

Compound 4, dose for half-maximal effect: > 100 mg/kg
Compound 4: no number, only a limit; the forecaster's own chance of this, stated with the estimate: 60%; the middle value lies on the limit itself.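

In this assay compound 4 gives > 100 mg/kg as a limit of the assay and not a number. The steps among compound 2, compound 3 and compound 4 cannot be read, so changing the chain at this place shows neither a size nor a direction, and the limit now covers one more chain length: the limit of > 100 mg/kg in this assay, at which 3 of the 4 values shown sit. Within the data shown here, the one readable step is the first to compare methyl with phenyl on an aromatic carbon at the same chain, and it is beyond the scatter: an at least 3.1-fold higher number from compound 1 to compound 4 (0.49 log units; beyond the scatter).

From the compounds shown here alone, only the lower bound of that step is known, so how much the change from phenyl to methyl costs remains open. The compounds shown also leave open how an ethyl or a benzyl on that aromatic carbon would behave, and whether phenyl would give a number on the longer chains of compound 2 and compound 3.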